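This account rests on a few compounds, and the source may have more. Where it says the series, first, only, none or still open, it means among the compounds named here.

Measured compounds:
compound 1 `CNC(=O)[C@@]12C[C@@H]1[C@@H](n1cnc3c(/C=C(\O)c4ccccc4Cl)nc(C#Cc4ccccc4Cl)nc31)[C@H](O)[C@@H]2O` — in an assay on CHO cells for displacement of a labelled ligand from adenosine receptor A1 (Homo sapiens), read by scintillation counting, with a stated time of 60 min, tested at 10 uM (on this read-out lower numbers stand for less inhibition and higher numbers for more inhibition at the one concentration tested (going by the name of the read-out)), compound 1 gives 28%
compound 2 `CNC(=O)[C@@]12C[C@@H]1[C@@H](n1cnc3cnc(C#Cc4ccc(Cl)s4)nc31)[C@H](O)[C@@H]2O` — in this assay compound 2 gives < 10%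
compound 3 `CNC(=O)[C@@]12C[C@@H]1[C@@H](n1cnc3c(C)nc(C#Cc4ccccc4)nc31)[C@H](O)[C@@H]2O` — in this assay compound 3 gives 15%

The reading for compound 2 is a limit of the assay and not a number. Compound 2 therefore sits at the floor of what is shown, at the limit of < 10% in this assay, at which 1 of the 3 values shown sits. Compound 4 `CNC(=O)[C@@]12C[C@@H]1[C@@H](n1cnc3cnc(/C=C(\O)c4cnccn4)nc31)[C@H](O)[C@@H]2O` differs from compound 2 in one place: 2-hydroxy-2-(pyrazin-2-yl)ethenyl in place of 2-(5-chlorothiophen-2-yl)ethynyl on an aromatic carbon. Among the compounds with values here, no comparable pair has been measured, so the direction of this change is open. Compound 4 is expected to move only modestly, by about a number at least 5 percentage points higher from compound 2 to compound 4 (that floor lies within the scatter) from the limit of compound 2. The estimate for compound 4 in this assay is 15%, with a range from 5% to 35%.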

Compound 4, a percentage reported as inhibition, at one concentration (the size of the read-out at that concentration, not a potency): 14%
Compound 4: middle estimate off by 1 percentage points, on the high side, within the range that was stated.
By their numbers in this assay, from the lowest: compounds 4 and 3 (each within the scatter of the next); then compound 1. At a limit, below all of these: compound 2.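

Within the data shown here, this is the first comparison at the aromatic carbon between two ring nitrogen atoms, and in this assay the change to 2-hydroxy-2-(pyrazin-2-yl)ethenyl from 2-(5-chlorothiophen-2-yl)ethynyl gives a number at least 4 percentage points higher from compound 2 to compound 4 (that floor lies within the scatter). The swap of a triple-bonded thiophene group for a double-bonded pyrazine group therefore shows no change beyond the scatter. Compound 2 stands at a limit of the assay and not at a number: the limit of < 10% in this assay, at which 1 of the 4 values shown sits.

Going by these compounds, the true size of the step remains open. So does how an amine or a carboxylic acid at this same carbon would read.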